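The source may report more compounds than this note shows. Statements on the series, on what has been measured and on what is new or still open speak of the compounds shown alone.

Compound 1 `O=S(=O)(Nc1cc(CO)ccc1O)c1ccc(-c2ccc(Br)cc2)cc1` is measured in a functional assay on J774 cells (Mus musculus) for cytotoxicity, read by resazurin assay, with a stated time of 72 h (on this read-out lower numbers stand for stronger inhibition and higher numbers for weaker inhibition), where compound 1 gives 1000 nM. Among the three numbers shown, compound 1 stands second highest: compound 2 `O=S(=O)(Nc1cc(CO)ccc1O)c1ccc(-c2ccc(F)cc2F)cc1` gives 200 nM, and compound 3 `O=S(=O)(Nc1cc(CO)cc(CO)c1)c1ccc(-c2ccc(Cl)cc2Cl)cc1` gives 2500 nM. Among the measured compounds shown here, the only step between two compounds that differ in a single place is a 5.0-fold lower number from compound 1 to compound 2 (0.70 log units; beyond the scatter). Compound 4 `Cc1ccc(CO)cc1NS(=O)(=O)c1ccc(-c2ccc(Br)cc2)cc1` differs from compound 1 by methyl in place of hydroxy on an aromatic carbon. For the measured compounds named here, no measured step covers this change; compound 3 differs from compound 1 in more than one place, so its value gives no single guide. Without a direct precedent, only a small shift is expected, with no firm direction. The estimate for compound 4 is 1500 nM, with a range from 400 nM to 6000 nM, which means that a 1.5-fold higher number from compound 1 to compound 4 (0.18 log units; within the scatter) is expected.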

Compound 4, half-maximal inhibitory concentration: > 5000 nM
Compound 4: only a limit was reported (the forecaster's own chance of this, stated with the estimate: 10%); middle value at least 3.3-fold (0.52 log units) away from the limit.
By their numbers in this assay, from the lowest: compound 2; then compound 1; then compound 3. At a limit, above all of these: compound 4.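

Among the compounds shown here, the only earlier step changed the 4-bromophenyl group, whereas this one shows that the hydroxy position also counts in this assay: methyl in place of hydroxy gives an at least 5.0-fold higher number from compound 1 to compound 4 (0.69 log units; beyond the scatter), a shift towards weaker inhibition. For compound 4 the assay gives > 5000 nM, which is a limit and not a number, so the full size of the step stays unknown: the limit of > 5000 nM in this assay, at which 1 of the 4 values shown sits.

The compounds shown leave open how an amine or a methoxy group would read at this place. They also leave open whether the 2,4-difluorophenyl group of compound 2 would keep its lower number with methyl there.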